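From Compound 1 to Compound 4: a Ring Exchange

The source may hold more compounds than are shown below. What is called first, only, known or untested is meant among the compounds shown, and "the series" means these compounds.

Compound 1 `CC1CCN(C2CCN(S(=O)(=O)c3ccc(Cl)c(Cl)c3)CC2)CC1` was tested for toxicity to a human colon cancer cell line in an ADME assay on HCT-116 cells (Homo sapiens) for cytotoxicity, read by CellTiter-Glo, with a stated time of 72 h; a higher number here means a weaker inhibitor, a lower number a stronger inhibitor. In this assay compound 1 gives > 5000 nM, which is a limit of the assay rather than a measured number. Compound 2 `CC1CCN(C2CCN(S(=O)(=O)c3ccc(Cl)c(C(F)(F)F)c3)CC2)CC1` and compound 3 `CC1CCN(C2CCN(S(=O)(=O)c3ccc(-c4ccccc4F)cc3)CC2)CC1` share the same core. In this assay compound 2 gives > 5000 nM, again only a limit. In this assay compound 3 gives > 5000 nM, also a limit. Going by the values given here, the single step between measured neighbours, a step that the two limits leave unreadable from compound 1 to compound 2, therefore has no readable size. Compound 4 `CC1CCN(C2CCN(S(=O)(=O)c3ccc(Cl)nc3)CC2)CC1` has not yet been measured. It differs from compound 1 in one place: 6-chloropyridin-3-yl in place of 3,4-dichlorophenyl on a sulfonyl sulfur. Among the compounds with values here, no measured step touches this part of the molecule, so nothing points to a move in either direction; what is known is simply (the limit of > 5000 nM in this assay, at which 3 of the 3 values shown sit). Compound 4 is therefore expected to sit at the same limit, with an estimated step that the limit leaves unreadable from compound 1 to compound 4. The estimate for compound 4 is 8000 nM, with a range from 3000 nM to 30000 nM.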

Compound 4, half-maximal inhibitory concentration: > 10000 nM
Compound 4: a limit, no number; the forecaster's own chance of this, stated with the estimate: 85%; at least 1.2-fold (0.09 log units) between middle value and limit.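

In this assay compound 4 gives > 10000 nM, which is a limit and not a number. Going by these compounds alone, compound 1 also stands only at a limit, so no step between compound 1 and compound 4 can be read. The compounds shown leave open the concentration at which any of them would reach half-maximal inhibition.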